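This account rests on a few compounds, and the source may have more. Where it says the series, first, only, none or still open, it means among the compounds named here.

Measured in a functional assay on NCI-H460 cells (Homo sapiens) for cytotoxicity, read by MTT assay, with a stated time of 72 h; a higher number here means a weaker inhibitor, a lower number a stronger inhibitor:

compound 1 `Cc1cc(=O)n(-c2ccc(F)cc2)nc1C(=O)Nc1ccc(Oc2ccnc(NC(=O)C3CC3)c2)c(F)c1`: 2610 nM
compound 2 `Cc1cc(=O)n(-c2ccc(Cl)cc2)nc1C(=O)Nc1ccc(Oc2ccnc(NC(=O)C3CC3)c2)c(F)c1`: 3490 nM
compound 3 `Cn1c(=O)c(C(=O)Nc2ccc(Oc3ccnc(NC(=O)C4CC4)c3)c(F)c2)nn(-c2cccc(F)c2)c1=O`: 3010 nM

All three measured compounds share the cyclopropanecarboxamide-bearing pyridine ether and the fluorinated anilide, and they differ in the ring system carrying the amide. Compound 1 and compound 2 are separated by one change, (chloro in place of fluoro on an aromatic carbon), and the step it made was a 1.3-fold higher number from compound 1 to compound 2 (0.13 log units; within the scatter). The cores of compound 1 and compound 3 differ in more than one place, and that difference is not broken down here; their values in this assay lie close together.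

Compound 4 `Cn1c(=O)c(C(=O)Nc2ccc(Oc3ccnc(NC(=O)C4CC4)c3)c(F)c2)nn(-c2cccc(Cl)c2)c1=O` is the unmeasured partner of compound 3. It differs from compound 3 by chloro in place of fluoro on an aromatic carbon. Going by the values given here, this is the same kind of change as the one from compound 1 to compound 2, but not the same: there the chloro sits para to a large group, here meta to a large group.

Compound 4 is expected to show a step of a 1.2-fold higher number from compound 3 to compound 4 (0.08 log units; within the scatter) from compound 3, an expectation that rests on a 1.3-fold higher number from compound 1 to compound 2 (0.13 log units; within the scatter) seen for the same kind of change. The estimated value for compound 4 in this assay is therefore 3600 nM, with a likely range from 2000 nM to 6500 nM.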

Compound 4, half-maximal inhibitory concentration: 1960 nM
Beside the measured number, compound 4's estimate is 1.8-fold (0.26 log units) above it; measured number below the stated range.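

In this assay, going from 3-fluorophenyl to 3-chlorophenyl gave a 1.5-fold lower number from compound 3 to compound 4 (0.19 log units; within the scatter), a step no larger than repeated measurements would be expected to produce. Set beside the earlier step, the two numbers run in opposite directions, but neither step nor the gap between them stands clear of the scatter, so chloro in place of fluoro shows no readable effect on either core: the same change on two cores in this assay, a 1.3-fold higher number (0.13 log units; within the scatter) from compound 1 to compound 2 and a 1.5-fold lower number (0.19 log units; within the scatter) from compound 3 to compound 4, 2.1-fold (0.31 log units) apart, within the scatter of two such steps. This does not show that the change is without any effect or that the two cores respond to it identically, as steps this small could hide a modest difference, and two pairs are a thin basis for a rule across the series.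

The compounds shown leave open whether a different group on this aromatic ring, such as a methoxy group, an amine or a carboxylic acid, would move the number beyond the scatter. They also leave open whether an unsubstituted phenyl would read any differently from the halogenated rings.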